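This account rests on a few compounds, and the source may have more. Where it says the series, first, only, none or still open, it means among the compounds named here.

Going by the values given here, compound 2 `c1cn2cc(-c3ccsc3)nc(-c3ccc4ncn(C5CCCCC5)c4c3)c2n1` stands level with the only other measured compound: in a functional assay on ACHN cells (Homo sapiens) for inhibition, read by sulforhodamine B assay, with a stated time of 48 h, tested at 10 uM (on this read-out lower numbers stand for less inhibition and higher numbers for more inhibition at the one concentration tested (going by the name of the read-out)), compound 2 gives 5.76%, and compound 1 `c1ccc2c(-c3cn4ccnc4c(-c4ccc5ncn(C6CCCCC6)c5c4)n3)cccc2c1` gives 6.49%, the two numbers lying within the scatter of each other. The change to compound 3 `CC(=O)c1ccc(-c2cn3ccnc3c(-c3ccc4ncn(C5CCCCC5)c4c3)n2)cc1` is 4-acetylphenyl in place of thiophen-3-yl on an aromatic carbon. Among the compounds with values here, one measured step bears on it, the exchange of aromatic groups at the same place, a number 0.7 percentage points lower from compound 1 to compound 2 (within the scatter), which stayed within the scatter. Within the data shown here, both measured compounds sit near the floor of the read-out, and the single step available gives no sign that varying the aryl group at this position moves the number. The step to compound 3 is therefore expected to be a number 0.2 percentage points higher from compound 2 to compound 3 (within the scatter), with nothing beyond the scatter. Compound 3 is estimated at 6% in this assay, with a range from -3% to 16%.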

Compound 3, a percentage reported as inhibition, at one concentration (the size of the read-out at that concentration, not a potency): 4.32%
Estimate against measurement, compound 3: 1.7 percentage points above, within the range that was stated.
By their numbers in this assay, from the lowest: compounds 3, 2 and 1 (each within the scatter of the next).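

In this assay, 4-acetylphenyl at this aromatic carbon gives a number that stays within the scatter of both earlier compounds (a number 1.4 percentage points lower from compound 2 to compound 3 (within the scatter)) and (a number 2.2 percentage points lower from compound 1 to compound 3 (within the scatter)). Going by these compounds alone, the earlier step compared only thiophen-3-yl with naphthalen-1-yl, two groups without a substituent; this change adds a carbonyl and a double bond outside the aromatic rings, and still no step leaves the scatter, so all three compounds remain level at this single concentration. No supporting data bear on why this position is so flat.

As far as these compounds go, whether an amine or a carboxylic acid on the aryl ring, or a longer chain in place of the aryl group, would move the number beyond the scatter stays open. Also open, from the compounds shown here alone, is whether changes elsewhere on the shared core, such as replacing the cyclohexyl group, would do so.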